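This account rests on a few compounds, and the source may have more. Where it says the series, first, only, none or still open, it means among the compounds named here.

Compound 2 `CC(=O)OC[C@H]1O[C@@H](n2cc(CN3C(=O)/C(=C\c4ccc(N(C)C)cc4)c4ccccc43)nn2)[C@H](OC(C)=O)[C@@H](OC(C)=O)[C@@H]1OC(C)=O` carries a 4-(dimethylamino)phenyl group on a double-bonded chain carbon of its shared core. Within the data shown here, in a functional assay on A549 cells (Homo sapiens) for cytotoxicity, read by sulforhodamine B assay, with a stated time of 48 h (on this read-out higher numbers stand for weaker inhibition and lower numbers for stronger inhibition), compound 2 gives 17700 nM, the lowest of the two numbers measured so far. Among the measured compounds shown here, its only measured neighbour is compound 1 `CC(=O)OC[C@H]1O[C@@H](n2cc(CN3C(=O)/C(=C\C=C\c4ccccc4)c4ccccc43)nn2)[C@H](OC(C)=O)[C@@H](OC(C)=O)[C@@H]1OC(C)=O`, which in this assay gives 58400 nM; the single step of a 3.3-fold lower number from compound 1 to compound 2 (0.52 log units; beyond the scatter) shows that swapping the group on that chain carbon can move the read-out by a modest but real amount.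

Compound 3 `CC(=O)OC[C@H]1O[C@@H](n2cc(CN3C(=O)/C(=C\c4cccs4)c4ccccc43)nn2)[C@H](OC(C)=O)[C@@H](OC(C)=O)[C@@H]1OC(C)=O` changes the same place once more: thiophen-2-yl in place of 4-(dimethylamino)phenyl on a double-bonded chain carbon bound to a double-bonded ring carbon. For the measured compounds named here, no measured pair tests a thiophen-2-yl at this position, so the only guide is the step from compound 1 to compound 2, which shows the read-out responds to the ring at this chain carbon. A change away from the group that gave the lowest number is expected to move the read-out back upward by a 1.8-fold higher number from compound 2 to compound 3 (0.26 log units; within the scatter), a step of modest size, though a result within the scatter cannot be excluded. Compound 3 is therefore expected to give about 32000 nM in this assay, with a plausible range from 10000 nM to 90000 nM.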

Compound 3, half-maximal inhibitory concentration: 16100 nM
The estimate for compound 3 lay 2.0-fold (0.30 log units) above the measured number; the measured number falls inside the stated range.
By their numbers in this assay, from the lowest: compounds 3 and 2 (each within the scatter of the next); then compound 1.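

In this assay thiophen-2-yl and 4-(dimethylamino)phenyl cannot be told apart at this chain carbon: the exchange gives a 1.1-fold lower number from compound 2 to compound 3 (0.04 log units; within the scatter) even though a five-membered aromatic ring with 1 hetero atom and 5 heavy atoms enters and a six-membered aromatic ring of carbon only, counted with its substituent as 9 heavy atoms, leaves. The earlier step could have reflected something particular to 4-(dimethylamino)phenyl, but thiophen-2-yl in place of 2-phenylethenyl gives a 3.6-fold lower number from compound 1 to compound 3 (0.56 log units; beyond the scatter) and so also ends beyond the scatter, alongside a 3.3-fold lower number from compound 1 to compound 2 (0.52 log units; beyond the scatter) for the other replacement. No measurement shown explains the match between the two ring groups or the higher number of the 2-phenylethenyl compound.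

From the compounds shown here alone, whether a plain phenyl, a saturated morpholine ring or a phenyl bearing a carboxylic acid at this chain carbon would give a number close to these two or move clearly away remains open. The compounds shown also keep the rest of the shared core unchanged, so they say nothing about how the read-out responds to changes elsewhere.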